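A few compounds are considered here, and "the series" means these few. Any claim that something is new, unique, unknown or untested is made for them only; others in the source may bear on it.

Compounds measured so far:
compound 1 `Cc1cccc(/C=N/Nc2ncc3c(n2)n(C2CCCC2)c(=O)c(=O)n3C)c1`, 53600 nM;
compound 2 `Cn1c(=O)c(=O)n(C2CCCC2)c2nc(N/N=C/c3cccc(Cl)c3Cl)ncc21`, 17200 nM;
compound 3 `Cc1ccc(/C=N/Nc2ncc3c(n2)n(C2CCCC2)c(=O)c(=O)n3C)cc1C`, 39000 nM.

All three were examined in a functional assay on PC-3 cells (Homo sapiens) for antiproliferative activity, read by MTT assay; a lower number here means a stronger inhibitor, a higher number a weaker inhibitor. Among them compound 3 stands second highest; its nearest neighbour is compound 1, its furthest compound 2, and the step of a 2.3-fold higher number from compound 2 to compound 3 (0.36 log units; beyond the scatter) was modest, while compound 1 and compound 3 lie within the scatter of each other. Compound 4 `Cn1c(=O)c(=O)n(C2CCCC2)c2nc(N/N=C/c3cccc([N+](=O)[O-])c3)ncc21` differs from compound 3 only in the aryl group: 3-nitrophenyl in place of 3,4-dimethylphenyl on a carbon with a double bond to nitrogen. Going by the values given here, the steps that bear on this are the aryl replacements a 3.1-fold lower number from compound 1 to compound 2 (0.49 log units; beyond the scatter) and a 2.3-fold higher number from compound 2 to compound 3 (0.36 log units; beyond the scatter), both modest. A modest step toward a lower number is therefore expected for compound 4, a 1.5-fold lower number from compound 3 to compound 4 (0.18 log units; within the scatter), though a change within the scatter cannot be excluded. Compound 4 is estimated at 26000 nM, in the range 10000 nM to 65000 nM.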

Compound 4, half-maximal inhibitory concentration: 20300 nM
Compound 4: the middle estimate sits 1.3-fold (0.11 log units) above what was measured; the measured number falls inside the stated range.
By their numbers in this assay, from the lowest: compounds 2, 4, 3 and 1 (each within the scatter of the next, the first and the last beyond it).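

On the carbon with a double bond to nitrogen, 3-nitrophenyl brings hydrogen-bond acceptors that 3,4-dimethylphenyl lacks, yet the change gives only a 1.9-fold lower number from compound 3 to compound 4 (0.28 log units; within the scatter) and so cannot be told apart from the scatter. Against 2,3-dichlorophenyl, the swap gives a 1.2-fold higher number from compound 2 to compound 4 (0.07 log units; within the scatter) and is equally unresolved, so only the nitro for methyl change, with a 2.6-fold lower number from compound 1 to compound 4 (0.42 log units; beyond the scatter), clears the scatter. Nothing available explains these numbers.

On these data alone, whether an amine or a carboxylic acid in this aryl group would move the number beyond these compounds remains open, as does how a plain phenyl group would compare.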